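Aryl ether extension on the triazole-bearing sulfonamide hydroxamate

This account rests on a few compounds, and the source may have more. Where it says the series, first, only, none or still open, it means among the compounds named here.

Compound 2 `COc1ccc(S(=O)(=O)N(CCn2cc(CCCF)nn2)[C@@H](C(=O)NO)C(C)C)cc1` gives 0.07 nM in an assay on isolated protein for inhibition of matrix metalloproteinase-9 (Homo sapiens), read by fluorescence, with a stated time of 30 min (a lower number here means a stronger inhibitor, a higher number a weaker inhibitor), the lowest number of the three measured; compound 3 `COc1ccc(S(=O)(=O)N(CCn2cc(CN(C)S(=O)(=O)c3ccc(F)cc3)nn2)[C@@H](C(=O)NO)C(C)C)cc1` gives 3 nM and compound 1 `CC(C)[C@H](C(=O)NO)N(CCN=[N+]=[N-])S(=O)(=O)c1ccc(OCCF)cc1` gives 4 nM. Compound 4 `CC(C)[C@H](C(=O)NO)N(CCn1cc(CCCF)nn1)S(=O)(=O)c1ccc(OCCF)cc1` carries fluoromethyl in place of hydrogen on a saturated chain carbon bound to an oxygen on an aromatic ring, so methoxy becomes 2-fluoroethoxy. Among the compounds with values here, the only single-point step recorded, a 43-fold higher number from compound 2 to compound 3 (1.63 log units; beyond the scatter), concerns the triazole substituent rather than the aryl ether and does not bear on this change. Compound 1 also carries 2-fluoroethoxy, but it differs from compound 2 at the side chain as well, so its value cannot be read as a step at the ether. Within the data shown here, with no direct precedent, a change within or near the scatter is expected, a 1.7-fold higher number from compound 2 to compound 4 (0.23 log units; within the scatter). Compound 4 is therefore estimated at 0.12 nM, range 0.03 nM to 0.5 nM.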

Compound 4, half-maximal inhibitory concentration: 2 nM
Compound 4: middle estimate off by 17-fold (1.22 log units), on the low side, outside the stated range (above it).
By their numbers in this assay, from the lowest: compound 2; then compounds 4, 3 and 1 (each within the scatter of the next).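

Methoxy to 2-fluoroethoxy is not a neutral change at this position: with the triazole side chain held fixed, this assay gives a 29-fold higher number from compound 2 to compound 4 (1.46 log units; beyond the scatter) for this change alone. With 2-fluoroethoxy in place, the side-chain exchange gives a 2.0-fold lower number from compound 1 to compound 4 (0.30 log units; within the scatter) and so does not separate the azide from the triazole. No available evidence accounts for the size of the ether step.

Ethoxy, without fluorine, would show whether the step follows the fluorine or the added carbon. 3-Fluoropropoxy would test a longer chain at the same oxygen.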